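Cyclohexyl in Place of Furan on a Shared Core

A few compounds are considered here, and "the series" means these few. Any claim that something is new, unique, unknown or untested is made for them only; others in the source may bear on it.

Measured so far:
- Compound 1, `Cc1nn(C)c2nc(NNC(=O)Nc3cc(Cl)nc(Cl)c3)cc(-c3ccco3)c12`: 69200 nM in a functional assay on HCT-116 cells (Homo sapiens) for cytotoxicity, read by MTT assay, with a stated time of 48 h, in the presence of a further agent that is not named here; on this read-out lower numbers stand for an effect already at smaller amounts and higher numbers for an effect only at larger amounts of compound
- Compound 2, `Cn1ncc2c(-c3ccc(F)cc3)cc(NNC(=O)Nc3cc(F)cc(F)c3)nc21`: 46200 nM in this assay
- Compound 3, `COc1cc(NC(=O)NNc2cc(-c3ccccc3)c3cnn(C)c3n2)cc(Cl)n1`: 31300 nM in this assay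

Among these three, compound 1 has the highest number. Compound 2 sits within the usual scatter of compound 1, so the two cannot be told apart on this read-out. Compound 3 lies beyond the scatter, with a lower number than compound 1, meaning its effect appears at smaller amounts.

Compound 4, `Cc1nn(C)c2nc(NNC(=O)Nc3cc(Cl)nc(Cl)c3)cc(C3CCCCC3)c12`, has not yet been measured. It differs from compound 1 in one place: cyclohexyl in place of furan-2-yl on an aromatic carbon. For the measured compounds named here, no measured pair isolates this change, so the size of its step is unknown from the data at hand. Given that all three measured values lie in a narrow band, the step in this assay from compound 1 to compound 4 is expected to be modest, possibly none beyond the scatter, in either direction. Compound 4 is therefore estimated at 60000 nM, with a range from 25000 nM to 150000 nM, which corresponds to an expected step of a 1.2-fold lower number from compound 1 to compound 4 (0.06 log units; within the scatter).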

Compound 4, half-maximal effective concentration: 38000 nM
Compound 4: middle estimate off by 1.6-fold (0.20 log units), on the high side; measured number inside the range.
By their numbers in this assay, from the lowest: compounds 3, 4, 2 and 1 (each within the scatter of the next, the first and the last beyond it).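

In this assay, replacing furan-2-yl with cyclohexyl on this aromatic carbon gives the first directly comparable pair, and the step (a 1.8-fold lower number from compound 1 to compound 4 (0.26 log units; within the scatter)) stays within the usual scatter. At this position, then, a five-membered aromatic ring with an oxygen and a six-membered non-aromatic ring of carbon only cannot be told apart on this read-out, even though the hydrogen-bond acceptor counted in furan-2-yl is gone. Nothing available here explains this outcome.

As far as these compounds go, whether a ring-free group such as a short alkyl chain, or a group carrying an amine or a carboxylic acid, would move the number beyond the scatter at this position remains open. For the compounds shown here, with only one pair, it is also unknown whether this swap would give a similar step with other groups elsewhere on the shared core.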